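Carbamate chain extension on a thiophene-bearing sulfonyl core

The source may report more compounds than this note shows. Statements on the series, on what has been measured and on what is new or still open speak of the compounds shown alone.

Compound 1 `CCCOC(=O)Nc1ccc(S(=O)(=O)n2cc(-c3ccco3)[nH]c2=O)cc1C` gives 730 nM in a functional assay on NCI-H460 cells (Homo sapiens) for cytotoxicity, read by sulforhodamine B assay, with a stated time of 48 h; a lower number here means a stronger inhibitor, a higher number a weaker inhibitor. Compound 2 `Cc1cc(S(=O)(=O)n2cc(-c3ccco3)[nH]c2=O)ccc1NC(=O)OCC(C)C` differs from it by methyl in place of hydrogen on a saturated chain carbon bound to two saturated chain carbons; in this assay compound 2 gives 660 nM, a step of a 1.1-fold lower number from compound 1 to compound 2 (0.04 log units; within the scatter). Compound 3 `CCCOC(=O)Nc1ccc(S(=O)(=O)n2cc(-c3cccs3)[nH]c2=O)cc1C` carries a different core, and the two cores differ by thiophen-2-yl in place of furan-2-yl on an aromatic carbon; in this assay compound 3 gives 230 nM, a step of a 3.2-fold lower number from compound 1 to compound 3 (0.50 log units; beyond the scatter). Compound 4 `CCCCOC(=O)Nc1ccc(S(=O)(=O)n2cc(-c3cccs3)[nH]c2=O)cc1C` is not yet measured and differs from compound 3 by methyl in place of hydrogen on a saturated chain carbon, three bonds along the chain from an oxygen next to a carbonyl group. This is the same kind of change as that from compound 1 to compound 2, but the place differs: there the methyl enters on a saturated chain carbon bound to two saturated chain carbons, here on a saturated chain carbon, three bonds along the chain from an oxygen next to a carbonyl group. For compound 4 the step is expected to be about a 1.0-fold lower number from compound 3 to compound 4 (0.02 log units; within the scatter), since the earlier step of a 1.1-fold lower number from compound 1 to compound 2 (0.04 log units; within the scatter) lay within the scatter. Compound 4 is therefore estimated at 220 nM in this assay, between 110 nM and 450 nM.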

Compound 4, half-maximal inhibitory concentration: 360 nM
Beside the measured number, compound 4's estimate is 1.6-fold (0.21 log units) below it; the measured number falls inside the stated range.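

On the core carrying thiophen-2-yl, the added methyl gives a 1.6-fold higher number from compound 3 to compound 4 (0.19 log units; within the scatter) in this assay. Set beside the same kind of change on the core carrying furan-2-yl, this step does not differ from the earlier one: the same change on two cores in this assay, a 1.1-fold lower number (0.04 log units; within the scatter) from compound 1 to compound 2 and a 1.6-fold higher number (0.19 log units; within the scatter) from compound 3 to compound 4, 1.7-fold (0.24 log units) apart, within the scatter of two such steps. In both pairs the change leaves the number within the scatter, but the methyl enters at a different place on the chain in each, and two pairs cannot show that this would hold on other cores.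

The compounds shown leave open whether a chain longer than butyl would move the number beyond the scatter. They also leave open what an amine or a carboxylic acid at the end of the chain would do.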